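The source may report more compounds than this note shows. Statements on the series, on what has been measured and on what is new or still open speak of the compounds shown alone.

Measured in a functional assay on HCT-116 cells (Homo sapiens) for antiproliferative activity, read by MTT assay, with a stated time of 48 h; on this read-out lower numbers stand for stronger inhibition and higher numbers for weaker inhibition:
- compound 1 `COc1cc(C(=O)/C=C/c2ccc(OCCCC(=O)NCCCCN(CCCN)CCCCN)cc2)cc(OC)c1OC`: 29200 nM
- compound 2 `COc1cc(C(=O)/C=C/c2ccc(OCCCC(=O)NCCCNCCCCN)cc2)cc(OC)c1OC`: > 100000 nM (a limit, not a number)
- compound 3 `COc1ccc(/C=C/C(=O)c2cc(OC)c(OC)c(OC)c2)cc1OCCCC(=O)NCCCCN(CCCN)CCCCN`: 73600 nM

Compound 2 stands at the limit of > 100000 nM in this assay, at which 1 of the 3 values shown sits, so it has no exact value. Compound 4 `COc1cc(C(=O)/C=C/c2ccc(OCCCC(=O)NCCCNCCCCNCCN)cc2)cc(OC)c1OC` carries 2-aminoethyl in place of hydrogen on an amine nitrogen of compound 2: 2-aminoethyl in place of hydrogen on an amine nitrogen. Among the measured compounds shown here, the one measured step in this amine chain is an at least 3.4-fold higher number from compound 1 to compound 2 (0.53 log units; beyond the scatter). Read in reverse, that step points to a lower number when an amine-bearing group is added, though the group differs here and the starting point is only a limit. A modest step towards a lower number is therefore expected, an at least 1.6-fold lower number from compound 2 to compound 4 (0.22 log units; that floor lies within the scatter). For compound 4 the estimate is 60000 nM, with an expected range of 25000 nM to 100000 nM.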

Compound 4, half-maximal inhibitory concentration in the HCT-116 assay: 33800 nM
For compound 4 the middle estimate is 1.8-fold (0.25 log units) above the measured one; the measured number falls inside the stated range.
By their numbers in the HCT-116 assay, from the lowest: compounds 1 and 4 (each within the scatter of the next); then compound 3. At a limit, above all of these: compound 2.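

In the HCT-116 assay compound 2 carries a limit, > 100000 nM, and not a number. With 2-aminoethyl in place of hydrogen on this amine nitrogen, the series shows an at least 2.9-fold lower number from compound 2 to compound 4 (0.47 log units; beyond the scatter), so substitution at this nitrogen brings the read-out within the measurable range. Two differently built amine chains also read alike, with a 1.2-fold higher number from compound 1 to compound 4 (0.06 log units; within the scatter).

As far as these compounds go, whether a longer chain such as 3-aminopropyl, or a carboxylic acid, on this nitrogen would move the number further stays open. In a physicochemical assay for lipophilicity, read by spectrophotometry, measured as octanol-water partition, tested at 300 uM (on this read-out higher numbers stand for higher lipophilicity and lower numbers for lower lipophilicity), compound 2 gives -1.43 and compound 4 gives -1.98. Also open is whether the physicochemical assay follows the antiproliferative read-out beyond this one pair: the measured partition coefficient of compound 2, -1.43, and of compound 4, -1.98, a number 0.55 log units lower (beyond the scatter)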